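A fluoro for methyl swap on the shared core

The compounds below may be only part of what the source reports. "The series", "measured", "known", "first", "only" and "open" are said of these compounds alone.

compound 1, `CCCc1nc(-c2ccccc2)c(CNCCN2CCN(c3cccc(C)c3)CC2)o1`: 43.1%
compound 2, `CCCc1nc(-c2ccccc2)c(CNCCCN2CCN(c3cccc(F)c3)CC2)o1`: 68.9%
compound 3, `CCCc1nc(-c2ccccc2)c(CNCCCN2CCN(c3cccc(OC)c3)CC2)o1`: 36.4%

All three compounds were measured in an assay on HEK293 cells for inhibition of Voltage-dependent T-type calcium channel subunit alpha-1G (Homo sapiens), read by fluorescence, tested at 10 uM; a higher number here means more inhibition at the concentration tested (going by the name of the read-out), a lower number less inhibition. Compound 1 sits well below compound 2, a gap beyond the scatter, and close to compound 3, a gap within the scatter, so no order can be read between compound 1 and compound 3. Compound 4, `CCCc1nc(-c2ccccc2)c(CNCCN2CCN(c3cccc(F)c3)CC2)o1`, differs from compound 1 by fluoro in place of methyl on an aromatic carbon. Among the compounds with values here, only one measured step touches this position: a number 32.5 percentage points lower from compound 2 to compound 3 (beyond the scatter), a large loss. Within the data shown here, no measured pair shows methyl against fluoro directly, and compound 2 differs from compound 1 in a second place as well, so the comparison is indirect. Still, the fluoro compound 2 gives the largest number of the three, while the methoxy compound 3 lies close to the methyl compound 1. A moderate rise is therefore expected for compound 4, with wide uncertainty. Compound 4 is estimated at 55%, within a range from 38% to 72%. The expected step is a number 11.9 percentage points higher from compound 1 to compound 4 (beyond the scatter).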

Compound 4, a percentage reported as inhibition, at one concentration (the size of the read-out at that concentration, not a potency): 62.3%
Compound 4: middle estimate off by 7.3 percentage points, on the low side; measured number inside the range.
By their numbers in this assay, from the lowest: compounds 3 and 1 (each within the scatter of the next); then compounds 4 and 2 (each within the scatter of the next).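

In this assay the change from 3-methylphenyl to 3-fluorophenyl gives a number 19.2 percentage points higher from compound 1 to compound 4 (beyond the scatter) and so sets fluoro directly against methyl at this place on the ring. Within the data shown here, the earlier compounds could not do this, since their only step here, methoxy in place of fluoro, involves compounds that differ from compound 1 in a second place as well. The step is modest and rests on this single pair, and nothing available explains why fluoro gives the higher number here.

On these data alone, how chloro, trifluoromethyl or a nitrile would compare with fluoro at this place remains open. As far as these compounds go, it is also open whether swapping methyl for fluoro would give a similar step on the core of compound 2.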